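Removing the Fluorine and Shifting the Pyridine Attachment Point

This account rests on a few compounds, and the source may have more. Where it says the series, first, only, none or still open, it means among the compounds named here.

Of the compounds shown here, two with a shared core have been measured in an assay on cells for binding affinity to Orexin/Hypocretin receptor type 1 (Homo sapiens), read by radioligand binding; on this read-out lower numbers stand for stronger inhibition and higher numbers for weaker inhibition. Compound 1, `Cc1ccc(-n2nccn2)c(C(=O)N2C[C@H](C#Cc3cncc(CO)c3)CC[C@H]2C)c1`, gives 108 nM. Among the measured compounds shown here, compound 2, `Cc1ccc(-n2nccn2)c(C(=O)N2C[C@H](C#Cc3ccc(F)cn3)CC[C@H]2C)c1`, gives 1.1 nM, the lowest of the two numbers; the only measured step, a 98-fold lower number from compound 1 to compound 2 (1.99 log units; beyond the scatter), separates them. The unmeasured compound 3 is `Cc1ccc(-n2nccn2)c(C(=O)N2C[C@H](C#Cc3cccnc3)CC[C@H]2C)c1`, differing from compound 2 by pyridin-3-yl in place of 5-fluoropyridin-2-yl on a triple-bonded carbon. For the measured compounds named here, no measured step isolates either the loss of fluorine or the change of attachment point on its own; the single step from compound 1 to compound 2 bundles both together with the loss of the hydroxymethyl group, and was large. Compound 3 removes the fluorine and shifts the attachment point toward that of compound 1 while lacking its hydroxymethyl group, so compound 3 is expected to show a step of a 9.1-fold higher number from compound 2 to compound 3 (0.96 log units; beyond the scatter), landing between the two measured numbers. Compound 3 is therefore estimated at 10 nM, within 2 nM to 60 nM.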

Compound 3, inhibition constant: 107 nM
Compound 3: the middle estimate sits 11-fold (1.03 log units) below what was measured, and the stated range ends below it.
By their numbers in this assay, from the lowest: compound 2; then compounds 3 and 1 (each within the scatter of the next).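

In this assay, hydrogen in place of hydroxymethyl on an aromatic carbon gives a 1.0-fold lower number from compound 1 to compound 3 (0.00 log units; within the scatter) and so leaves no readable difference between these two compounds. The large gap in the series therefore goes with the ring on the triple-bonded carbon, as the step of a 97-fold higher number from compound 2 to compound 3 (1.99 log units; beyond the scatter) shows with no hydroxymethyl group involved. No measurement given here accounts for the size of this step.

Going by these compounds, the step still joins the loss of fluorine and the change of attachment point, so the share of each stays open; 5-fluoropyridin-3-yl or pyridin-2-yl on the same carbon would separate them. On these data alone, it is also open whether an amine or a carboxylic acid in the place of hydroxymethyl would match compound 3 as closely as compound 1 does.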